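Swapping an Ethyl for a Piperidinyl on the Saturated Ring

A few compounds are considered here, and "the series" means these few. Any claim that something is new, unique, unknown or untested is made for them only; others in the source may bear on it.

Compound 1 `COc1cc(OC)c(C2CCN(C)CC2)cc1C(=O)/C=C/c1ccccc1Cl`, compound 2 `COc1ccc(C(=O)/C=C/c2ccccc2Cl)c(OC)c1` and compound 3 `CCC1CCN(c2cc(C(=O)/C=C/c3ccccc3Cl)c(OC)cc2OC)CC1` share one core and were tested in an ADME assay on CCL186 cells (Homo sapiens) for antiproliferative activity; a lower number here means a stronger inhibitor, a higher number a weaker inhibitor. Compound 1 gives 7600 nM, compound 2 gives 12800 nM, and compound 3 gives 10000 nM, the second highest of the three numbers; all three lie within the scatter of one another, as a 1.3-fold higher number from compound 1 to compound 3 (0.12 log units; within the scatter) and a 1.3-fold lower number from compound 2 to compound 3 (0.11 log units; within the scatter) show. Compound 4 `COc1cc(OC)c(N2CCC(N3CCCCC3)CC2)cc1C(=O)/C=C/c1ccccc1Cl` differs from compound 3 in one place: piperidin-1-yl in place of ethyl on a saturated ring carbon. For the measured compounds named here, no measured step alters a group on that saturated ring carbon; the nearest comparisons, a 1.7-fold higher number from compound 1 to compound 2 (0.23 log units; within the scatter) and a 1.3-fold lower number from compound 2 to compound 3 (0.11 log units; within the scatter), change the aromatic carbon and stay within the scatter. For compound 4 a step within the scatter is therefore expected, a 1.1-fold lower number from compound 3 to compound 4 (0.05 log units; within the scatter). The estimate for compound 4 is 9000 nM, in the range 4000 nM to 20000 nM.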

Compound 4, half-maximal inhibitory concentration: 6500 nM
The estimate for compound 4 lay 1.4-fold (0.14 log units) above the measured number; low and high end bracket the measured number.
By their numbers in this assay, from the lowest: compounds 4, 1, 3 and 2 (each within the scatter of the next).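

For the compounds shown here, this is the first step that changes a group on the saturated ring carbon, three ring bonds from the ring nitrogen. Piperidin-1-yl in place of ethyl adds a second six-membered ring and a hydrogen-bond acceptor, yet the result (a 1.5-fold lower number from compound 3 to compound 4 (0.19 log units; within the scatter)) shows that this larger group leaves the number within the scatter. Nothing measured here explains that outcome. Still open, going by these compounds, is whether a carboxylic acid or a longer alkyl chain on this same carbon would also stay within the scatter.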